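Changing the Six-Membered Ring on the Thiocarbonyl Carbon

The compounds below may be only part of what the source reports. "The series", "measured", "known", "first", "only" and "open" are said of these compounds alone.

Measured so far:
compound 1 `Cc1cccc(/C(N)=N/NC(=S)N2CCSCC2)n1` gives 46.8%
compound 2 `Cc1cccc(/C(N)=N/NC(=S)N2CCOCC2)n1` gives 74.7%

In a functional assay on MCF7 cells (Homo sapiens) for cytotoxicity, read by MTT assay, with a stated time of 72 h, tested at 100 uM (on this read-out higher numbers stand for more inhibition of growth at the one concentration tested and lower numbers for less inhibition of growth), compound 2 holds the higher of the two numbers, and the step of a number 27.9 percentage points higher from compound 1 to compound 2 (beyond the scatter) lies beyond the scatter. Compound 3 `Cc1cccc(/C(N)=N/NC(=S)N2CCCCC2)n1` differs from compound 2 by piperidin-1-yl in place of morpholin-4-yl on a thiocarbonyl carbon. Within the data shown here, no measured step exchanges the morpholin-4-yl ring for a ring with a single hetero atom, so the one known step is only a loose guide: it shows that this ring can shift the read-out substantially, in either direction. The expected change is therefore a number 14.7 percentage points lower from compound 2 to compound 3 (beyond the scatter), with wide uncertainty. Compound 3 is estimated at 60%, ranging from 30% to 85%.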

Compound 3, percent growth inhibition at one concentration: 54%
The estimate for compound 3 lay 6 percentage points above the measured number; low and high end bracket the measured number.
By their numbers in this assay, from the lowest: compounds 1 and 3 (each within the scatter of the next); then compound 2.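

In this assay, piperidin-1-yl in place of morpholin-4-yl gives a number 20.7 percentage points lower from compound 2 to compound 3 (beyond the scatter) and so the drop seen with thiomorpholin-4-yl is not specific to that ring. Piperidin-1-yl in place of thiomorpholin-4-yl gives a number 7.2 percentage points higher from compound 1 to compound 3 (within the scatter) and so these two rings cannot be told apart here. Among the three rings on the thiocarbonyl carbon, only the morpholin-4-yl ring of compound 2 stands apart.

Going by these compounds, how a piperazin-1-yl ring or an open-chain dimethylamino group would fare at this carbon remains open. Nothing available explains why the morpholin-4-yl ring stands apart.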